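Nitrocatechol chalcones against monoamine oxidase A: a phenol variant

A few compounds are considered here, and "the series" means these few. Any claim that something is new, unique, unknown or untested is made for them only; others in the source may bear on it.

Compound 1 `O=C(/C=C/c1ccoc1)c1cc(O)c(O)c([N+](=O)[O-])c1`: 52900 nM
Compound 2 `O=C(/C=C/c1nccs1)c1cc(O)c(O)c([N+](=O)[O-])c1`: 69600 nM
Compound 3 `CC(=O)N1N=C(c2cc(O)c(O)c([N+](=O)[O-])c2)CC1c1ccco1`: 98000 nM

Of the compounds shown here, three sharing the nitrocatechol core have been measured in an assay on isolated protein for inhibition of Amine oxidase [flavin-containing] A (Homo sapiens), read by fluorescence; on this read-out higher numbers stand for weaker inhibition and lower numbers for stronger inhibition. Compound 1 gives the lowest of the three numbers, but all three lie within the usual scatter of one another, so no order among them can be read from these values. Within the data shown here, the one step that changes a single group, from compound 1 to compound 2 , replaces the five-membered ring with another five-membered ring and shifts the number only slightly: a 1.3-fold higher number from compound 1 to compound 2 (0.12 log units; within the scatter). Compound 3 carries a different linker and is not directly comparable by a single change; its value simply sits close to the other two.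

Compound 4 `O=C(/C=C/c1cccc(O)c1)c1cc(O)c(O)c([N+](=O)[O-])c1` differs from compound 1 as follows: 3-hydroxyphenyl in place of furan-3-yl on a double-bonded chain carbon bound to a double-bonded chain carbon. Among the measured compounds shown here, the only measured step at this position, from compound 1 to compound 2 , stayed within the scatter, so the swap to a six-membered carbon-only ring bearing a hydroxyl offers no precedent for a step beyond the scatter in this assay , in either direction. Compound 4 is therefore expected to give about 50000 nM, within a range of 20000 nM to 130000 nM. The expected step from compound 1 is a 1.1-fold lower number from compound 1 to compound 4 (0.02 log units; within the scatter), which would be no more than the scatter itself.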

Compound 4, half-maximal inhibitory concentration: 43900 nM
The estimate for compound 4 lay 1.1-fold (0.06 log units) above the measured number; the range from low to high includes it.
By their numbers in this assay, from the lowest: compounds 4, 1, 2 and 3 (each within the scatter of the next, the first and the last beyond it).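

In this assay, the place on a double-bonded chain carbon bound to a double-bonded chain carbon now holds a six-membered aromatic ring of carbon only, where the earlier step had compared only five-membered rings, and the numbers stay within the scatter: a 1.2-fold lower number from compound 1 to compound 4 (0.08 log units; within the scatter), and a 1.6-fold lower number from compound 2 to compound 4 (0.20 log units; within the scatter). The entering 3-hydroxyphenyl has 7 heavy atoms and 1 hydrogen-bond donor, against 5 heavy atoms and 0 hydrogen-bond donors for furan-3-yl, yet this larger change in the group leaves the number as indistinguishable as the swap between the two five-membered rings did. No measurement at hand bears on why these three rings give such similar numbers.

As far as these compounds go, what the hydroxyl contributes on its own stays open, as a plain phenyl group would be needed to separate it from the ring that carries it. Also open, from the compounds shown here alone, is whether an amine or a carboxylic acid on that ring, or a longer chain at this place, would move the number beyond the scatter in either direction.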